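Swapping the Hydantoin Arm for a Thiazolidinedione

A few compounds are considered here, and "the series" means these few. Any claim that something is new, unique, unknown or untested is made for them only; others in the source may bear on it.

Of the compounds shown here, three that share one core have been measured in a physicochemical assay for lipophilicity, read by HPLC, measured as octanol-water partition; on this read-out lower numbers stand for lower lipophilicity and higher numbers for higher lipophilicity. Compound 1 `O=C1O[C@@H](CO)CN1c1ccc(-n2cc(-c3ccccn3)cn2)c(F)c1` gives 1.67. Compound 2 `CCN1CCN(C[C@H]2CN(c3ccc(-n4cc(-c5ccccn5)cn4)c(F)c3)C(=O)O2)CC1` gives 2.19. Compound 3 `O=C1CNC(=O)N1C[C@H]1CN(c2ccc(-n3cc(-c4ccccn4)cn3)c(F)c2)C(=O)O1` gives 1.25, the lowest of the three numbers. The measured steps show how the group on the saturated chain carbon bound to a saturated ring carbon shifts the reading in this assay: a number 0.52 log units higher from compound 1 to compound 2 (beyond the scatter), a number 0.42 log units lower from compound 1 to compound 3 (beyond the scatter), and a number 0.94 log units lower from compound 2 to compound 3 (beyond the scatter).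

Compound 4 `O=C1CSC(=O)N1C[C@H]1CN(c2ccc(-n3cc(-c4ccccn4)cn3)c(F)c2)C(=O)O1` has not yet been measured. It differs from compound 3 in one place: 2,4-dioxo-1,3-thiazolidin-3-yl in place of 2,5-dioxoimidazolidin-1-yl on a saturated chain carbon bound to a saturated ring carbon. Within the data shown here, none of the measured steps exchanges one five-membered ring for another at this position, so they bear on the question only indirectly: the steps to compound 3 show that the 2,5-dioxoimidazolidin-1-yl group gave the lowest number of the set, leaving room above it. Since the two groups are of equal size and the change is smaller than either measured exchange, the step from compound 3 to compound 4 in this assay is expected to be small and upward, a number 0.35 log units higher from compound 3 to compound 4 (beyond the scatter), and could still fall within the scatter. Compound 4 is therefore estimated to give 1.6, with a range from 1.2 to 2.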

Compound 4, partition coefficient: 2.18
Estimate against measurement, compound 4: 0.58 log units below; measured number outside the range, above it.
By their numbers in this assay, from the lowest: compound 3; then compound 1; then compounds 4 and 2 (each within the scatter of the next).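

On a saturated chain carbon bound to a saturated ring carbon, exchanging one five-membered ring for another with the same count of 7 heavy atoms gives a number 0.93 log units higher from compound 3 to compound 4 (beyond the scatter) in this assay, a step close in size to the exchange of two very different groups, a number 0.94 log units lower from compound 2 to compound 3 (beyond the scatter) on the same carbon. Ring size and heavy-atom count therefore do not fix the reading here, since the 2,4-dioxo-1,3-thiazolidin-3-yl group differs from the 2,5-dioxoimidazolidin-1-yl group only in having a sulfur in place of a nitrogen, and 0 hydrogen-bond donors against 1. The new ring also gives a number 0.51 log units higher from compound 1 to compound 4 (beyond the scatter) against hydroxy, while a number 0.01 log units lower from compound 2 to compound 4 (within the scatter) leaves it indistinguishable from the unlike 4-ethylpiperazin-1-yl group in this read-out.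

Nothing available explains the step or divides it between the sulfur and the lost donor. A 3-methyl-2,5-dioxoimidazolidin-1-yl group, which keeps the nitrogen but has a methyl in place of the amide hydrogen, and a 2,4-dioxo-1,3-oxazolidin-3-yl group, which has an oxygen where the sulfur stands, would pull those two changes apart, and neither is among the compounds shown.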